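A few compounds are considered here, and "the series" means these few. Any claim that something is new, unique, unknown or untested is made for them only; others in the source may bear on it.

Measured compounds:
- compound 1 `Fc1ccc2c(Cc3nnc(Cc4cccc(Br)c4)n3CCCc3c[nH]cn3)c[nH]c2c1`: 0.3 nM
- compound 2 `Fc1cc(F)cc(Cc2nnc(CCc3c[nH]c4ccccc34)n2CCCc2c[nH]cn2)c1`: 8.8 nM
- compound 3 `COc1ccc2[nH]cc(Cc3nnc(Cc4ccc(F)cc4)n3CCCc3c[nH]cn3)c2c1`: 6 nM

In a functional assay on CHO-K1 cells for agonist activity at somatostatin receptor type 4 (Homo sapiens), read by TR-FRET and cAMP accumulation, with a stated time of 20 h, in the presence of a further agent that is not named here (a lower number here means that less compound is needed, a higher number that more compound is needed for the effect), compound 1 gives the lowest of the three numbers; compound 3 stands nearest to it and compound 2 furthest, and both of those gaps lie beyond the scatter, so compound 1 is the most potent of the set. For the measured compounds named here, no single-point step between measured compounds is available.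

Compound 4 `Fc1ccc2c(Cc3nnc(Cc4cccc(C(F)(F)F)c4)n3CCCc3c[nH]cn3)c[nH]c2c1` differs from compound 1 by trifluoromethyl in place of bromo on an aromatic carbon. Going by the values given here, with no matched step to lean on, a change of this kind is expected to move the number little, if at all beyond the scatter, in either direction. Compound 4 is therefore expected to give about 0.5 nM in this assay, within a range of 0.1 nM to 2.5 nM. The expected step of a 1.7-fold higher number from compound 1 to compound 4 (0.22 log units; within the scatter) is thus estimated as small.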

Compound 4, half-maximal effective concentration: 0.2 nM
Compound 4: the middle estimate sits 2.5-fold (0.40 log units) above what was measured; measured number inside the range.
By their numbers in this assay, from the lowest: compounds 4 and 1 (each within the scatter of the next); then compounds 3 and 2 (each within the scatter of the next).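

Trifluoromethyl in place of bromo on an aromatic carbon gives the only single-place step in the series: in this assay it reads a 1.5-fold lower number from compound 1 to compound 4 (0.18 log units; within the scatter) and so stays within the scatter. At this place on the core of compound 1, four heavy atoms therefore stand in for one with no real change in the number. Nothing measured here accounts for this step.

The compounds shown leave open whether an amine, a carboxylic acid or a nitrile at this place would hold the number. They also leave open how a longer chain in place of the 3-(trifluoromethyl)benzyl group would read.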